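Propylamino Replacing Ethyl on the Shared Core

The compounds below may be only part of what the source reports. "The series", "measured", "known", "first", "only" and "open" are said of these compounds alone.

Going by the values given here, compound 2 `CCCOc1ccc(C(=O)Nc2cccc(CC)n2)cc1` gives 29200 nM in an in vitro assay on HEK-tsA201 cells for antagonist activity at Neuronal acetylcholine receptor; alpha3/beta4 (Homo sapiens), read by fluorescence and calcium flux (on this read-out lower numbers stand for stronger inhibition and higher numbers for weaker inhibition), the higher of the two numbers measured so far. Its nearest neighbour, compound 1 `CCCOc1ccc(C(=O)Nc2cccc(C)n2)cc1`, gives 11100 nM in this assay, and the step of a 2.6-fold higher number from compound 1 to compound 2 (0.42 log units; beyond the scatter) was modest yet beyond the scatter. Compound 3 `CCCNc1cccc(NC(=O)c2ccc(OCCC)cc2)n1` differs from compound 2 by propylamino in place of ethyl on an aromatic carbon. Among the compounds with values here, no measured step exchanges a saturated chain for a nitrogen-bearing group on the shared core, so that earlier modest step is the only guide, and a change of similar size in either direction remains open. The estimate for compound 3 in this assay is 30000 nM, between 8000 nM and 120000 nM. That expectation amounts to a 1.0-fold higher number from compound 2 to compound 3 (0.01 log units; within the scatter).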

Compound 3, half-maximal inhibitory concentration: 12600 nM
The estimate for compound 3 lay 2.4-fold (0.38 log units) above the measured number; low and high end bracket the measured number.
By their numbers in this assay, from the lowest: compounds 1 and 3 (each within the scatter of the next); then compound 2.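

In this assay propylamino in place of ethyl gives a 2.3-fold lower number from compound 2 to compound 3 (0.37 log units; beyond the scatter) and so runs against the earlier rise from methyl to ethyl: across these three compounds, the number does not climb steadily as the group on this aromatic carbon grows. Propylamino in place of methyl gives a 1.1-fold higher number from compound 1 to compound 3 (0.06 log units; within the scatter) and so shows that this position accepts the longer nitrogen-bearing group without the loss seen with ethyl. Nothing measured here accounts for this change.

From the compounds shown here alone, whether the lower number goes with the ring-bound nitrogen or with the chain itself stays open. A butyl chain or a methylamino group at this position would separate the two.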